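This account rests on a few compounds, and the source may have more. Where it says the series, first, only, none or still open, it means among the compounds named here.

Measured in a functional assay on SK-BR-3 cells (Homo sapiens) for antiproliferative activity; a lower number here means a stronger inhibitor, a higher number a weaker inhibitor:
- compound 1 `CC(C)=CCc1cc(C(=O)Nc2cc3ccc(OCCCN4CCCC4)c(C)c3oc2=O)ccc1O`: 720 nM
- compound 2 `CCCNCCCOc1ccc2cc(NC(=O)c3ccc(O)c(CC=C(C)C)c3)c(=O)oc2c1C`: 990 nM
- compound 3 `CC(C)=CCc1cc(C(=O)Nc2cc3ccc(OCCCNC(C)(C)C)c(C)c3oc2=O)ccc1O`: 660 nM

Compound 3, at 660 nM, lies within the scatter of both other compounds, so the three values form a single level with no order among them.

The next compound is compound 4 `CC(C)=CCc1cc(C(=O)Nc2cc3ccc(OCCCN(C)C4CCCCC4)c(C)c3oc2=O)ccc1O`, which carries cyclohexyl(methyl)amino in place of (tert-butyl)amino on a saturated chain carbon, three bonds along the chain from an oxygen on an aromatic ring.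

All three measured steps change the amine at this same place, and each stays within the scatter: a 1.4-fold higher number from compound 1 to compound 2 (0.14 log units; within the scatter), a 1.1-fold lower number from compound 1 to compound 3 (0.04 log units; within the scatter) and a 1.5-fold lower number from compound 2 to compound 3 (0.18 log units; within the scatter). Among the compounds with values here, the pyrrolidin-1-yl of compound 1 is the only ring-bearing amine measured so far, but no measured compound carries cyclohexyl(methyl)amino. The three compounds therefore support only a cautious reading, and a wider range is warranted than their close agreement alone would suggest.

With the amine changes so far giving a 1.1-fold lower number from compound 1 to compound 3 (0.04 log units; within the scatter) and a 1.5-fold lower number from compound 2 to compound 3 (0.18 log units; within the scatter), no step beyond the scatter is expected in this assay, and no direction can be called. The estimate means a 1.1-fold higher number from compound 3 to compound 4 (0.03 log units; within the scatter), an expected step that stays small.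

For compound 4 the expected value is 700 nM, with an estimated range of 300 nM to 1600 nM.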

Compound 4, half-maximal inhibitory concentration: 970 nM
Beside the measured number, compound 4's estimate is 1.4-fold (0.14 log units) below it; the range from low to high includes it.
By their numbers in this assay, from the lowest: compounds 3, 1, 4 and 2 (each within the scatter of the next).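

In this assay, cyclohexyl(methyl)amino is a larger amine at this place than (tert-butyl)amino, with 8 heavy atoms against 5, a six-membered non-aromatic ring of carbon only and 0 hydrogen-bond donors against 1, yet the change gives a 1.5-fold higher number from compound 3 to compound 4 (0.17 log units; within the scatter). The other two amines compare in the same way, with a 1.0-fold lower number from compound 2 to compound 4 (0.01 log units; within the scatter) and a 1.3-fold higher number from compound 1 to compound 4 (0.13 log units; within the scatter), so all three new steps stay within the scatter and compounds 1, 2, 3 and 4 form a single level. On a saturated chain carbon, three bonds along the chain from an oxygen on an aromatic ring, these four amines therefore tolerate added bulk and the loss of the donor without a readable change in this assay, and no evidence on hand bears on why.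

From the compounds shown here alone, all four compounds keep a basic-type amine nitrogen on the same chain, so it remains open whether a carboxylic acid or a neutral amide at this place would leave the level intact. Also open, going by these compounds, is whether a longer chain, or a morpholin-4-yl or piperazin-1-yl in place of these amines, would produce a step beyond the scatter.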